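A few compounds are considered here, and "the series" means these few. Any claim that something is new, unique, unknown or untested is made for them only; others in the source may bear on it.

Compound 3, with the structure `COc1cc(-c2nnc(SC)n2-c2ccc(N(C)C)cc2)cc(OC)c1OC`, belongs to a small set of close relatives tested in a functional assay on HepG2 cells (Homo sapiens) for inhibition, read by MTT assay, with a stated time of 48 h; on this read-out lower numbers stand for stronger inhibition and higher numbers for weaker inhibition. In this assay compound 3 gives > 60000 nM, which is a limit of the assay and not a number. Compound 1, `COc1ccc(-n2c(SCC(=O)c3ccc4ccccc4c3)nnc2-c2cc(OC)c(OC)c(OC)c2)cc1`, carries a naphthalen-2-yl group on a carbonyl carbon; in this assay compound 1 gives > 60000 nM, again a limit. Compound 2, `COc1ccc(NC(=O)CSc2nnc(-c3cc(OC)c(OC)c(OC)c3)n2-c2ccc(OC)cc2)cc1`, also stops at a limit, giving > 60000 nM in this assay. The step from compound 1 to compound 2 reads a step that the two limits leave unreadable from compound 1 to compound 2, so it tells nothing about size or direction. Within the data shown here, what the set shows is summed up by the limit of > 60000 nM in this assay, at which 3 of the 3 values shown sit: no compound reaches a measurable value. Compound 4, `COc1ccc(C(=O)CSc2nnc(-c3cc(OC)c(OC)c(OC)c3)n2-c2ccc(N(C)C)cc2)cc1O`, differs from compound 3 by (3-hydroxy-4-methoxyphenyl)carbonyl in place of hydrogen on a saturated chain carbon bound to a sulfur. Compound 1 already holds a carbonyl on that same chain carbon and, as the limit of > 60000 nM in this assay, at which 3 of the 3 values shown sit, records, stays at the limit, so the new group gives no ground to expect a readable gain. The step from compound 3 to compound 4 is therefore expected to be a number no higher from compound 3 to compound 4 (the limit leaves the size open). Compound 4 is estimated at 60000 nM, with a range from 20000 nM to 200000 nM.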

Compound 4, half-maximal inhibitory concentration: > 100000 nM
Compound 4: only a limit was reported; the forecaster's own chance of this, stated with the estimate: 75%; at least 1.6-fold (0.22 log units) between middle value and limit.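

In this assay compound 4 gives > 100000 nM, a limit of the assay and not a number. Compound 3 also stops at a limit, so the step from compound 3 to compound 4 cannot be read. The compounds shown leave open which change, if any, would bring a measurable value.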